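Replacing an Inactive Aryl Group with Imidazolyl

A few compounds are considered here, and "the series" means these few. Any claim that something is new, unique, unknown or untested is made for them only; others in the source may bear on it.

Compound 3 `FC(F)(F)c1ccc(-c2nc(NCc3ccc(-c4cccnc4)cc3)c3ccccc3n2)cc1` gives "not active" (no number reported) in an assay on a protein complex for inhibition of ubiquitin carboxyl-terminal hydrolase 1/WD repeat-containing protein 48 (Homo sapiens), read by fluorescence (a higher number here means a weaker inhibitor, a lower number a stronger inhibitor), so it stands without a number among the measured compounds, whereas compound 1 `FC(F)(F)c1ccccc1-c1nc(NCc2ccccc2)c2ccccc2n1` gives 3100 nM and compound 2 `FC(F)(F)c1cc(-c2ccc(CNc3nc(-c4ccccc4C(F)(F)F)nc4ccccc34)cc2)ccn1` gives 4900 nM. Among the measured compounds shown here, the only measured step, a 1.6-fold higher number from compound 1 to compound 2 (0.20 log units; within the scatter), alters a different part of the shared core and therefore says little about the change that leads to compound 4 `c1cncc(-c2ccc(CNc3nc(-n4ccnc4)nc4ccccc34)cc2)c1`: 1H-imidazol-1-yl in place of 4-(trifluoromethyl)phenyl on an aromatic carbon. For the measured compounds named here, no measured step bears on this change, so no direction can be expected beyond the scatter, and the starting point itself has no number to build on. Compound 4 is therefore estimated at 30000 nM in this assay, with a range from 5000 nM to 200000 nM, and it may well again return no number at all.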

Compound 4, half-maximal inhibitory concentration: "not active" (no number reported)
For compound 4 the study gives words and no number; no gap can be computed for the estimate.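

Compound 3 and compound 4 both come back as not active with no number, so no step can be read between them, and nothing available explains this result. As far as these compounds go, whether 1H-imidazol-1-yl in place of 4-(trifluoromethyl)phenyl changes inhibition at all stays open.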